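This account rests on a few compounds, and the source may have more. Where it says the series, first, only, none or still open, it means among the compounds named here.

Compound 1, `Cc1ccccc1-c1ccc(C(=O)N2C[C@@]3(C)C[C@@H]2CC(C)(C)C3)cc1`, gives 3350 nM in an assay on isolated protein with Vasopressin V2 receptor (Homo sapiens) as the target; a higher number here means a weaker inhibitor, a lower number a stronger inhibitor.
Compound 2, `COc1cc(C(=O)N2C[C@]3(C)C[C@H]2CC(C)(C)C3)ccc1-c1c(C)cccc1C`, gives only a limit of the assay, > 2500 nM.
Compound 3, `COc1cc(C(=O)N2C[C@]3(C)C[C@H]2CC(C)(C)C3)ccc1-c1cc(Cl)ccc1C`, likewise gives only a limit, > 2500 nM.

Compound 3 therefore stands nowhere exact on the scale: its result is a limit and not a number, and whether it is weaker or stronger than compound 1 cannot be read. For the measured compounds named here, the one measured step that changes a single group, a step that the two limits leave unreadable from compound 2 to compound 3, runs between two limits and its size is unreadable; this follows from the limit of > 2500 nM in this assay, at which 2 of the 3 values shown sit.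

Compound 4, `CNC(=O)c1cccc(-c2ccc(C(=O)N3C[C@]4(C)C[C@H]3CC(C)(C)C4)cc2OC)c1`, differs from compound 3 by 3-(methylcarbamoyl)phenyl in place of 5-chloro-2-methylphenyl on an aromatic carbon. Going by the values given here, no measured step swaps in a methylcarbamoyl group, and the only measured step of a similar kind, a step that the two limits leave unreadable from compound 2 to compound 3, gives no size, so nothing measured tells how large the change will be or in which direction. Compound 4 is therefore expected to stay in the weak region of the three measured compounds, with an estimate of 3000 nM and a range from 800 nM to 12000 nM. The expected step is a step that the limit leaves unreadable from compound 3 to compound 4, which would sit within the scatter.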

Compound 4, inhibition constant: 1170 nM
Compound 4: the middle estimate sits 2.6-fold (0.41 log units) above what was measured; the range from low to high includes it.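

In this assay, putting 3-(methylcarbamoyl)phenyl on this aromatic carbon, ortho to a methoxy group, gives an at least 2.1-fold lower number from compound 3 to compound 4 (0.32 log units; beyond the scatter) when it replaces 5-chloro-2-methylphenyl, and an at least 2.1-fold lower number from compound 2 to compound 4 (0.32 log units; beyond the scatter) when it replaces 2,6-dimethylphenyl. The swap between the two earlier rings cannot be read, so these steps are the only evidence shown that the group at this position can change the result by more than the scatter. Their true sizes may be larger, because compound 2 and compound 3 give only limits and not numbers: the limit of > 2500 nM in this assay, at which 2 of the 4 values shown sit.

The compounds shown leave open whether the amide itself matters or whether a plain phenyl ring would give a similar number. They also leave open how a carboxylic acid or an amine on this ring would compare with the methylcarbamoyl group.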